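Trifluoromethyl for chloro, the same change on two cores

A few compounds are considered here, and "the series" means these few. Any claim that something is new, unique, unknown or untested is made for them only; others in the source may bear on it.

Compound 1 `COc1cc(-c2nn(-c3ccc(NC(=O)c4ccc(Cl)c(Cl)c4)cc3)cc2-c2ccncc2)ccc1Cl` and compound 2 `COc1cc(-c2nn(-c3ccc(NC(=O)c4ccc(Cl)c(C(F)(F)F)c4)cc3)cc2-c2ccncc2)ccc1Cl` share one core; compound 3 `O=C(Nc1ccc(-n2cc(-c3ccncc3)c(-c3ccc(Cl)c(O)c3)n2)cc1)Nc1ccc(Cl)c(Cl)c1` and compound 4 `O=C(Nc1ccc(-n2cc(-c3ccncc3)c(-c3ccc(Cl)c(O)c3)n2)cc1)Nc1ccc(Cl)c(C(F)(F)F)c1` share another. The difference between the two cores is not broken down here. In a functional assay on A375P cells (Homo sapiens) for antiproliferative activity, read by MTT assay, with a stated time of 48 h (a higher number here means a weaker inhibitor, a lower number a stronger inhibitor), compound 1 gives 13000 nM, compound 2 gives 9800 nM and compound 3 gives 13500 nM; all three numbers lie within the scatter of one another. The change trifluoromethyl in place of chloro on an aromatic carbon gave a 1.3-fold lower number from compound 1 to compound 2 (0.12 log units; within the scatter). The same change trifluoromethyl in place of chloro on an aromatic carbon is now made on the core of compound 3; the surroundings of the place read the same word for word, so this is the same kind of change on a different core. For compound 4 a step of about the same size is expected, a 1.4-fold lower number from compound 3 to compound 4 (0.13 log units; within the scatter), because the earlier step of a 1.3-fold lower number from compound 1 to compound 2 (0.12 log units; within the scatter) stayed within the scatter. Compound 4 is therefore estimated at 10000 nM, with a range from 5000 nM to 20000 nM.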

Compound 4, half-maximal inhibitory concentration: 14900 nM
Compound 4: middle estimate off by 1.5-fold (0.17 log units), on the low side, and the stated range covers the measured number.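

In this assay, trifluoromethyl in place of chloro on the core of compound 3 gave a 1.1-fold higher number from compound 3 to compound 4 (0.04 log units; within the scatter), so no effect of the change can be read on this core. The steps on the two cores do not differ: the same change on two cores in this assay, a 1.3-fold lower number (0.12 log units; within the scatter) from compound 1 to compound 2 and a 1.1-fold higher number (0.04 log units; within the scatter) from compound 3 to compound 4, 1.5-fold (0.17 log units) apart, within the scatter of two such steps. For the compounds shown here, this agreement shows only that the change stayed within the scatter on both cores; neither pair gives a step of real size, so it does not show that a measurable effect would carry from one core to another, and two pairs say nothing about other cores.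

Still open, going by these compounds, is whether an amine, a carboxylic acid or a nitrile at this place would give a step beyond the scatter on either core.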